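The source may report more compounds than this note shows. Statements on the series, on what has been measured and on what is new or still open speak of the compounds shown alone.

Working notes on the series. Compound 1 `Oc1ccccc1-c1cc(-c2cccc(F)c2)cc(-c2ccccc2O)n1` and compound 2 `Oc1ccccc1-c1cc(-c2ccc(F)cc2)cc(-c2ccccc2O)n1` share a core bearing two 2-hydroxyphenyl groups; compound 3 `Oc1ccc(-c2cc(-c3cccc(F)c3)cc(-c3cccc(O)c3)n2)cc1` carries a 3-hydroxyphenyl group and a 4-hydroxyphenyl group instead, and the difference between the two cores is not broken down here. In a functional assay on HCT-15 cells (Homo sapiens) for inhibition (on this read-out higher numbers stand for weaker inhibition and lower numbers for stronger inhibition), compound 1 returns only a limit, > 50000 nM. Compound 2 likewise returns a limit of > 50000 nM in this assay. Among the compounds with values here, compound 3 gives 3070 nM in this assay, the only number among the three. The change 4-fluorophenyl in place of 3-fluorophenyl on an aromatic carbon made a step that the two limits leave unreadable from compound 1 to compound 2; with both values sitting at the limit of > 50000 nM in this assay, at which 2 of the 3 values shown sit, its size cannot be read. Compound 4 `Oc1ccc(-c2cc(-c3ccc(F)cc3)cc(-c3cccc(O)c3)n2)cc1` carries the same kind of change, (4-fluorophenyl in place of 3-fluorophenyl on an aromatic carbon), though here the place is meta to a 3-hydroxyphenyl group and a 4-hydroxyphenyl group rather than to two 2-hydroxyphenyl groups. With no readable size from a step that the two limits leave unreadable from compound 1 to compound 2, the step is expected to stay small, a 1.0-fold lower number from compound 3 to compound 4 (0.01 log units; within the scatter). Compound 4 is estimated at 3000 nM in this assay, between 1000 nM and 10000 nM.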

Compound 4, half-maximal inhibitory concentration: 5020 nM
Compound 4: the middle estimate sits 1.7-fold (0.22 log units) below what was measured, within the range that was stated.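

In this assay, 4-fluorophenyl in place of 3-fluorophenyl opposite the ring nitrogen makes a 1.6-fold higher number from compound 3 to compound 4 (0.21 log units; within the scatter), so on this core the change leaves no step beyond the scatter. On the core bearing two 2-hydroxyphenyl groups, the same change cannot be read, because both values there are limits: the limit of > 50000 nM in this assay, at which 2 of the 4 values shown sit. Whether the change carries over from one core to the other is therefore not shown, since only one of the two steps has a readable size.

Left open is what each hydroxyphenyl group contributes on its own, as the two cores differ in more than one place. Also open, from the compounds shown here alone, is how a phenyl carrying an amine or a carboxylic acid would read opposite the ring nitrogen.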